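A few compounds are considered here, and "the series" means these few. Any claim that something is new, unique, unknown or untested is made for them only; others in the source may bear on it.

Measured in a functional assay on GBM3 cells (Homo sapiens) for antiproliferative activity, read by WST assay, with a stated time of 72 h; a lower number here means a stronger inhibitor, a higher number a weaker inhibitor:
- Compound 1 `O=C(Nc1ccc(Cl)c(Cl)c1)Nc1cc2ncncc2cc1OCc1ccccc1F`: > 10000 nM
- Compound 2 `O=C(Nc1ccc(Cl)c(Cl)c1)Nc1cc2ncncc2cc1OCc1cccc(F)c1`: 2000 nM

Compound 1 stands at the limit of > 10000 nM in this assay, at which 1 of the 2 values shown sits; this is a limit of this assay and not a number.

Compound 3 `O=C(Nc1ccccc1F)Nc1cc2ncncc2cc1OCc1ccccc1F` differs from compound 1 in one place: 2-fluorophenyl in place of 3,4-dichlorophenyl on an amide-type nitrogen. In words, 2-fluorophenyl takes the place of 3,4-dichlorophenyl on an amide-type nitrogen.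

Among the compounds with values here, no step at that nitrogen has been measured. Within the data shown here, the only measured step, an at least 5.0-fold lower number from compound 1 to compound 2 (0.69 log units; beyond the scatter), lies elsewhere, on a saturated chain carbon bound to an oxygen on an aromatic ring. It therefore bears on this change only indirectly. Among the measured compounds shown here, compound 3 keeps the 2-fluorophenyl group that was exchanged in an at least 5.0-fold lower number from compound 1 to compound 2 (0.69 log units; beyond the scatter), and the exchange of that group is the only change so far seen to give a measured number. With no measured support for a gain, no change beyond the scatter is expected in this assay, and compound 3 may well reach only a limit again.

The estimated step is a number no higher from compound 1 to compound 3 (the limit leaves the size open).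

For compound 3 the expected value is 10000 nM, with an estimated range of 3000 nM to 30000 nM.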

Compound 3, half-maximal inhibitory concentration: 3800 nM
Estimate against measurement, compound 3: 2.6-fold (0.42 log units) above, and the stated range covers the measured number.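

The amide-type nitrogen proves to be a second place where a change can matter in this assay: putting 2-fluorophenyl there in place of 3,4-dichlorophenyl gives an at least 2.6-fold lower number from compound 1 to compound 3 (0.42 log units; beyond the scatter). Until now, only the exchange on the saturated chain carbon had led to a measured number, so this result also shows that the 3,4-dichlorophenyl group is not required for one, at least while the 2-fluorophenyl group stays on that chain carbon. Compound 1 has only a limit of the assay and not a number, so the true size of this step remains unknown: the limit of > 10000 nM in this assay, at which 1 of the 3 values shown sits.

This single exchange removes both chlorine atoms and adds a fluorine atom, so the compounds shown cannot tell which part of the exchange matters, and a plain phenyl or a cyclohexyl group on the same nitrogen would help to separate these possibilities. It also remains open whether 2-fluorophenyl on the nitrogen would give a similar result when combined with the 3-fluorophenyl group of compound 2, as that combination is not among the compounds shown here.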